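The source may report more compounds than this note shows. Statements on the series, on what has been measured and on what is new or still open speak of the compounds shown alone.

Compounds measured in a functional assay on the whole organism (Hindlimb) for inhibition, with Mus musculus as the target, with a stated time of 1 h (on this read-out lower numbers stand for an effect already at smaller amounts and higher numbers for an effect only at larger amounts of compound), so far:
compound 1 `CCCC/N=C(\N)Nc1nnc(-c2ccccc2C(F)(F)F)s1` — 225 mg/kg
compound 2 `COCCC/N=C(\N)Nc1nnc(-c2ccccc2C(F)(F)F)s1` — 78 mg/kg

Compound 2 stands lowest of the two numbers in this assay; the step of a 2.9-fold lower number from compound 1 to compound 2 (0.46 log units; beyond the scatter) separates it from compound 1. Compound 3 `FC(F)(F)c1ccccc1-c1nnc(NC2=NCCN2)s1` is next. Relative to compound 2 it carries a group of 5 heavy atoms (3 carbon, 2 nitrogen; one five-membered non-aromatic ring with 2 hetero atoms) in place of a group of 8 heavy atoms (5 carbon, 2 nitrogen, 1 oxygen; no ring), on a nitrogen on an aromatic ring. For the measured compounds named here, the only measured step concerns a substituent on that same chain, not its replacement by a ring, so it bears on compound 3 only loosely; no direct precedent exists. Compound 3 is therefore estimated at 100 mg/kg (range 40 mg/kg to 250 mg/kg), a step of a 1.3-fold higher number from compound 2 to compound 3 (0.11 log units; within the scatter) expected to lie within the scatter.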

Compound 3, dose for half-maximal effect: > 100 mg/kg
Compound 3 gave a limit, no number; the forecaster's own chance of this, stated with the estimate: 10%; the middle value lies on the limit itself.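

In this assay compound 3 gives > 100 mg/kg, which is a limit and not a number. The five-membered non-aromatic ring with 2 hetero atoms in place of the open chain, on a nitrogen on an aromatic ring, gives an at least 1.2-fold higher number from compound 2 to compound 3 (0.10 log units; that floor lies within the scatter), so the ring's true distance from the chain is not fixed, and the other step to this compound cannot be read. The reading of this change therefore rests on a limit: the limit of > 100 mg/kg in this assay, at which 1 of the 3 values shown sits.

Still open, as far as these compounds go, is whether a measured number for the ring would lie close to compound 2 or far from it. Also open, from the compounds shown here alone, is how a longer chain, or an amine at the end of the chain, would read on this nitrogen.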